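Urea side-chain variation on the shared core

A few compounds are considered here, and "the series" means these few. Any claim that something is new, unique, unknown or untested is made for them only; others in the source may bear on it.

Three ureas on a shared core have been measured. Compound 1 `O=C(NCCN1CCCC1)Nc1cc2c(Nc3ccc(F)c(Cl)c3)ncnc2cc1O[C@H]1CCOC1` gives 247 nM in a functional assay on A-431 cells (Homo sapiens) for antiproliferative activity, read by sulforhodamine B assay, with a stated time of 72 h; a higher number here means a weaker inhibitor, a lower number a stronger inhibitor. Compound 2 `CCN(CC)CCN(C)C(=O)Nc1cc2c(Nc3ccc(F)c(Cl)c3)ncnc2cc1O[C@H]1CCOC1` gives 481 nM in this assay, and compound 3 `CN1CCN(C(=O)Nc2cc3c(Nc4ccc(F)c(Cl)c4)ncnc3cc2O[C@H]2CCOC2)CC1` gives 675 nM there. On these numbers compound 2 stands second highest of the three: a 1.9-fold higher number from compound 1 to compound 2 (0.29 log units; within the scatter) and a 1.4-fold higher number from compound 2 to compound 3 (0.15 log units; within the scatter) both fall within the scatter, while a 2.7-fold higher number from compound 1 to compound 3 (0.44 log units; beyond the scatter) is modest but beyond it. Compound 4 `C#CCNC(=O)Nc1cc2c(Nc3ccc(F)c(Cl)c3)ncnc2cc1O[C@H]1CCOC1` carries propargylamino in place of (2-(diethylamino)ethyl)(methyl)amino on a carbonyl carbon. Going by the values given here, no measured step removes the amine-bearing chain altogether. The three known steps only exchange one such chain for another and are small, so the expected step of a 1.4-fold higher number from compound 2 to compound 4 (0.13 log units; within the scatter) is modest at most, with a weaker inhibitor slightly favoured. Compound 4 is therefore estimated at 650 nM, range 250 nM to 1700 nM.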

Compound 4, half-maximal inhibitory concentration: 3730 nM
Compound 4: middle estimate off by 5.7-fold (0.76 log units), on the low side; the measured number lies above the stated range.
By their numbers in this assay, from the lowest: compounds 1, 2 and 3 (each within the scatter of the next, the first and the last beyond it); then compound 4.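

In this assay, propargylamino on the carbonyl carbon gives much larger steps than any among compounds 1, 2 and 3 (a 7.8-fold higher number from compound 2 to compound 4 (0.89 log units; beyond the scatter); a 5.5-fold higher number from compound 3 to compound 4 (0.74 log units; beyond the scatter)). The largest step (a 15-fold higher number from compound 1 to compound 4 (1.18 log units; beyond the scatter)) has ethynyl in place of (pyrrolidin-1-yl)methyl on a saturated chain carbon bound to an amide-type nitrogen, so among these four compounds, the highest number goes with the only side chain lacking a second amine. No evidence here accounts for this shift.

From the compounds shown here alone, whether the amine or the chain length matters more remains open. A plain propyl chain and a short dimethylaminoethyl chain on the same carbonyl carbon would separate the two.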